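The source may report more compounds than this note shows. Statements on the series, on what has been measured and on what is new or still open speak of the compounds shown alone.

Measured so far:
compound 1 `COc1cccc(-c2csc(N/N=C3\CCC(C)C3)n2)c1` — 231 nM
compound 2 `COc1cccc(-c2csc(N/N=C/c3cccnc3)n2)c1` — 2910 nM

Both compounds were tested in an assay on isolated protein for inhibition of Amine oxidase [flavin-containing] B (Homo sapiens), read by fluorescence; a higher number here means a weaker inhibitor, a lower number a stronger inhibitor. Of the two numbers, compound 1 holds the lower one, so it is the stronger inhibitor of the pair; compound 2 lies well beyond the scatter above it, and that gap is all the two measured values can tell. Among the compounds with values here, no pair of measured compounds differing in a single place has been compared, so there is no measured step to lean on when judging the next change.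

Compound 3 `CCC/C(C)=N/Nc1nc(-c2cccc(OC)c2)cs1` has not yet been measured in this assay. It differs from compound 1 by a group of 6 heavy atoms (5 carbon, 1 nitrogen; no ring) in place of a group of 7 heavy atoms (6 carbon, 1 nitrogen; one five-membered non-aromatic ring of carbon only), on a nitrogen on an aromatic ring. The rest of the molecule, including the shared core, stays as it is; only the group attached at that nitrogen is exchanged, a five-membered non-aromatic ring giving way to an open chain.

Without a measured step of this kind, the expectation is for a small change, within or just beyond the scatter, and if anything toward a weaker inhibitor. For compound 3 the estimate is 350 nM, with a likely range from 120 nM to 1000 nM, which would amount to an expected step of a 1.5-fold higher number from compound 1 to compound 3 (0.18 log units; within the scatter).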

Compound 3, half-maximal inhibitory concentration: 871 nM
For compound 3 the middle estimate is 2.5-fold (0.40 log units) below the measured one; low and high end bracket the measured number.
By their numbers in this assay, from the lowest: compound 1; then compound 3; then compound 2.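

In this assay, within the data shown here, this is the first measured step at the group on the nitrogen on an aromatic ring: putting an open chain in place of the group with the five-membered non-aromatic ring gives a 3.8-fold higher number from compound 1 to compound 3 (0.58 log units; beyond the scatter). The position therefore responds to this exchange, since the shared core stays the same and the step still lies beyond the usual scatter of repeated measurements. Nothing available here accounts for the size or direction of the step, as no separate measurement bears on this result.

This single step combines two differences, the loss of the ring and a change in the count of heavy atoms, so the compounds shown cannot separate one from the other. On these data alone, it also remains open whether a six-membered carbon ring in the same place would match or go beyond compound 1, and whether a longer chain would move the number up or down from that of compound 3.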